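Bromo to methoxy on the shared core

The compounds below may be only part of what the source reports. "The series", "measured", "known", "first", "only" and "open" are said of these compounds alone.

- compound 1 `O=C1/C(=C/c2cccc(Br)c2)Cc2ccccc21` gives 43300 nM
- compound 2 `Cc1ccc(/C=C2\Cc3ccccc3C2=O)cc1` gives 59100 nM
- compound 3 `COc1cccc(/C=C2\Cc3ccccc3C2=O)c1` is not yet measured

In a functional assay on L1210 cells (Mus musculus) for inhibition (on this read-out lower numbers stand for stronger inhibition and higher numbers for weaker inhibition), compound 1 at 43300 nM and compound 2 at 59100 nM lie within the scatter of each other, so compound 1 stands level with compound 2. Compound 3 has methoxy in place of bromo on an aromatic carbon, meta to a large group (methoxy in place of bromo on an aromatic carbon). Among the compounds with values here, no measured pair shows this change, so no step beyond the scatter is expected in this assay in either direction. The expected step is a 1.2-fold higher number from compound 1 to compound 3 (0.06 log units; within the scatter) and no more than that. Compound 3 is estimated at 50000 nM with an expected range of 20000 nM to 120000 nM in this series.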

Compound 3, half-maximal inhibitory concentration: 217000 nM
Estimate against measurement, compound 3: 4.3-fold (0.64 log units) below; measured number outside the range, above it.
By their numbers in this assay, from the lowest: compounds 1 and 2 (each within the scatter of the next); then compound 3.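

In this assay the change of bromo to methoxy on an aromatic carbon, meta to a large group, gives a 5.0-fold higher number from compound 1 to compound 3 (0.70 log units; beyond the scatter) and so shows that this position does not accept every group alike. Within the data shown here, this is the first step beyond the scatter, and it runs toward weaker inhibition. No measurement at hand explains the step.

Still open, from the compounds shown here alone, is whether the loss belongs to methoxy alone or extends to other groups here. An amine, a carboxylic acid or a longer chain such as ethoxy at this position would test that.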